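The source may hold more compounds than are shown below. What is called first, only, known or untested is meant among the compounds shown, and "the series" means these compounds.

Working notes on the series. Compound 1 `Oc1cc(C(F)(F)F)ccc1-c1nc(-c2ccccc2O)n(-c2ccc(Br)cc2)n1` in a functional assay on PC-12 cells (Rattus norvegicus) for cytotoxicity, read by MTT assay, with stated times of 2 h and 24 h, tested at 5 uM (on this read-out higher numbers stand for a stronger effect at the one concentration tested and lower numbers for a weaker effect), gives 89.8%. Compound 2 `Oc1cc(C(F)(F)F)ccc1-c1nc(-c2ccccc2O)n(-c2ccccc2F)n1` in this assay gives 86.6%. Among the two numbers recorded compound 2 stands lowest, its nearest neighbour being compound 1; the step of a number 3.2 percentage points lower from compound 1 to compound 2 (within the scatter) is within the scatter, so the two values cannot be ordered.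

Compound 3 `Cc1ccc(-n2nc(-c3ccc(C(F)(F)F)cc3O)nc2-c2ccccc2O)c(C)c1` has not yet been measured. Its change from compound 2 is 2,4-dimethylphenyl in place of 2-fluorophenyl on an aromatic nitrogen. For the measured compounds named here, the one measured step that bears on a change of the aryl group on an aromatic nitrogen is a number 3.2 percentage points lower from compound 1 to compound 2 (within the scatter), and it stayed within the scatter. On that basis no step beyond the scatter is expected here either. For compound 3 the expected step in this assay is a number 0.6 percentage points lower from compound 2 to compound 3 (within the scatter). Compound 3 is therefore estimated at 86%, with a range from 74% to 96%.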

Compound 3, a percentage reported as activity, at one concentration (the size of the read-out at that concentration, not a potency): 93.3%
Compound 3: the middle estimate sits 7.3 percentage points below what was measured, and the stated range covers the measured number.
By their numbers in this assay, from the lowest: compounds 2, 1 and 3 (each within the scatter of the next).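

With 2,4-dimethylphenyl on the aromatic nitrogen, the aryl group no longer carries a halogen, yet in this assay the step is a number 6.7 percentage points higher from compound 2 to compound 3 (within the scatter) and, against the bromo compound, a number 3.5 percentage points higher from compound 1 to compound 3 (within the scatter). The three aryl groups on this nitrogen (4-bromophenyl, 2-fluorophenyl and 2,4-dimethylphenyl) therefore cannot be ordered, and for these compounds neither halogen is needed to keep the read-out within the scatter of the others. No measurement is at hand that explains these numbers.

The shared core stays unchanged across these compounds, so its contribution, including that of the 2-hydroxyphenyl group, remains unresolved. Also open, going by these compounds, is whether an aryl group bearing an amine or a carboxylic acid, or a longer alkyl chain in place of the aryl group, would give a step beyond the scatter.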